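The source may report more compounds than this note shows. Statements on the series, on what has been measured and on what is new or still open speak of the compounds shown alone.

Measured compounds:
- compound 1, `CC(C)=CC[C@@H](OC(=O)c1ccoc1)C1=CC(=O)c2c(O)ccc(O)c2C1=O`: > 100000 nM in a functional assay on DU-145 cells (Homo sapiens) for cytotoxicity, read by MTT assay; on this read-out lower numbers stand for stronger inhibition and higher numbers for weaker inhibition
- compound 2, `COC(C)CO[C@H](CC=C(C)C)C1=CC(=O)c2c(O)ccc(O)c2C1=O`: 16600 nM

Compound 1 gives only a limit of the assay in this assay, namely > 100000 nM, so its true value is not pinned down; it sits at the limit of > 100000 nM in this assay, at which 1 of the 2 values shown sits. For the measured compounds named here, compound 2 is the only compound with a number, 16600 nM. Going by the values given here, the one measured step, an at least 6.0-fold lower number from compound 1 to compound 2 (0.77 log units; beyond the scatter), swaps the whole ester for an ether.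

The unmeasured compound 3, `CC[C@](C)(O)CC(=O)O[C@H](CC=C(C)C)C1=CC(=O)c2c(O)ccc(O)c2C1=O`, differs from compound 1 by 2-hydroxy-2-methylbutyl in place of furan-3-yl on a carbonyl carbon. The ester oxygen on the saturated carbon stays; only the acyl part changes. Among the compounds with values here, no measured step covers a change of this kind: the step from compound 1 to compound 2 removes the carbonyl altogether, so it bears on compound 3 only loosely, showing that a less bulky, non-aromatic group on that oxygen can move the number off the limit.

Compound 3 is therefore expected to stay weak, with a step of an at least 1.6-fold lower number from compound 1 to compound 3 (0.22 log units; that floor lies within the scatter) regarded as uncertain because the reference point is only a limit. The estimate for compound 3 is 60000 nM, with a range from 15000 nM to 200000 nM.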

Compound 3, half-maximal inhibitory concentration: 20500 nM
Beside the measured number, compound 3's estimate is 2.9-fold (0.47 log units) above it; measured number inside the range.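

In this assay, keeping the ester oxygen on the saturated carbon and changing only the acyl part is enough to bring the number off the limit, with an at least 4.8-fold lower number from compound 1 to compound 3 (0.68 log units; beyond the scatter). Removing the carbonyl is therefore not needed for this gain: the ester compound 3 and the ether compound 2 read alike, with a 1.2-fold higher number from compound 2 to compound 3 (0.09 log units; within the scatter). Compound 1 stays a limit of the assay, > 100000 nM, and not a number, so the step from it gives only a floor: the limit of > 100000 nM in this assay, at which 1 of the 3 values shown sits.

Open is which feature of the 2-hydroxy-2-methylbutyl group matters, whether its hydroxyl, its defined stereocentre or the loss of the furan-3-yl ring, as the compounds shown do not separate these. Also open, on these data alone, is how a plain butyl chain, a phenyl ring or an amine-bearing chain on the same carbonyl carbon would read in this assay, and whether any group at this place gives numbers well under those of compound 2 and compound 3.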